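The source may report more compounds than this note shows. Statements on the series, on what has been measured and on what is new or still open speak of the compounds shown alone.

Compound 1 `COc1cc(/C=C2\CN(C)C/C(=C\c3ccncc3)C2=O)cc(OC)c1OC`: 9800 nM
Compound 2 `CN1C/C(=C\c2ccncc2)C(=O)/C(=C/c2ccc(C#N)cc2)C1`: 13900 nM
Compound 3 `O=C1/C(=C/c2cccnc2)CN(S(=O)(=O)c2ccc([N+](=O)[O-])cc2)C/C1=C\c1ccccc1F`: 12800 nM

In a functional assay on HepG2 cells (Homo sapiens) for cytotoxicity, read by MTT assay, with a stated time of 24 h (on this read-out lower numbers stand for stronger inhibition and higher numbers for weaker inhibition), compound 3 at 12800 nM lies within the usual scatter of both compound 1 and compound 2, so the three cannot be ranked. Compound 4 `O=C1/C(=C/c2cccnc2)CN(S(=O)(=O)c2ccc(Br)cc2)C/C1=C\c1ccccc1F` has bromo in place of nitro on an aromatic carbon, a change from 4-nitrophenyl to 4-bromophenyl: bromo in place of nitro on an aromatic carbon. Within the data shown here, no measured pair shows this swap, so the data offer no direct guide. The best anchor is compound 3 itself, at 12800 nM. The expected change is a 1.2-fold lower number from compound 3 to compound 4 (0.07 log units; within the scatter), which would be no step beyond the scatter. For compound 4 the estimated value is 11000 nM, with an expected range from 5000 nM to 24000 nM.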

Compound 4, half-maximal inhibitory concentration: 8700 nM
The estimate for compound 4 lay 1.3-fold (0.10 log units) above the measured number; the measured number falls inside the stated range.
By their numbers in this assay, from the lowest: compounds 4, 1, 3 and 2 (each within the scatter of the next).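

Putting 4-bromophenyl where 4-nitrophenyl stood, on an otherwise unaltered compound, gives in this assay a 1.5-fold lower number from compound 3 to compound 4 (0.17 log units; within the scatter), the first step read at this position. Nitro and bromo, which differ in heavy atoms and hydrogen-bond acceptors, therefore cannot be told apart here, so this position shows no sensitivity to this particular swap. Nothing measured here bears on why this is so. As far as these compounds go, whether an amine or a carboxylic acid on that aromatic carbon would move the number beyond the scatter stays open. So does whether bromo and nitro would also match on a different core.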